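The compounds below may be only part of what the source reports. "The series", "measured", "known", "first", "only" and "open" are said of these compounds alone.

Compound 1, `O=C(/C=C/c1cn(S(=O)(=O)c2ccccc2[N+](=O)[O-])c2ccccc12)c1ccncc1`, is a member of a small set of indole-derived enones carrying a pyridyl ketone, examined for antiproliferative effect in a functional assay on MCF7 cells (Homo sapiens) for antiproliferative activity, read by MTT assay, with a stated time of 48 h; on this read-out higher numbers stand for weaker inhibition and lower numbers for stronger inhibition. In this assay compound 1 gives 36900 nM. The unsubstituted parent, compound 2, `O=C(/C=C/c1c[nH]c2ccccc12)c1ccncc1`, gives 45300 nM in this assay, and the two numbers lie within the scatter of each other, so no order between compound 1 and compound 2 can be read from them. The third measured member, compound 3, `O=C(/C=C/c1cn(S(=O)(=O)c2ccc(Cl)cc2Cl)c2ccccc12)c1ccncc1`, gives 12200 nM; "dose-dependent effect" (no number reported) (2 entries) in this assay, as set out in the several entries of compound 3 in this assay, 12200 nM; "dose-dependent effect" (no number reported) (2 entries); it carries a 2,4-dichlorophenyl group on the sulfonyl sulfur and its number is the lowest of the three.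

The step examined here leads from compound 1 to compound 4, `Cc1ccc(S(=O)(=O)n2cc(/C=C/C(=O)c3ccncc3)c3ccccc32)cc1`. The change is 4-methylphenyl in place of 2-nitrophenyl on a sulfonyl sulfur. Among the compounds with values here, since no measured pair differs in one place, no step size is known for this kind of exchange; compound 1 and compound 3 differ at the same sulfonyl substituent and their numbers lie beyond the scatter, but that pair swaps a different group. Compound 4 is expected to land close to compound 1, with the step of a 1.4-fold lower number from compound 1 to compound 4 (0.15 log units; within the scatter) estimated to stay within or only slightly beyond the scatter, toward a lower number. For compound 4 the estimate in this assay is 26000 nM, with a range from 9000 nM to 75000 nM.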

Compound 4, half-maximal inhibitory concentration: 48900 nM
Beside the measured number, compound 4's estimate is 1.9-fold (0.27 log units) below it; low and high end bracket the measured number.
By their numbers in this assay, from the lowest: compounds 1, 2 and 4 (each within the scatter of the next).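

In this assay, within the data shown here, 4-methylphenyl in place of 2-nitrophenyl on a sulfonyl sulfur gives the first measured step at this position, a 1.3-fold higher number from compound 1 to compound 4 (0.12 log units; within the scatter). At this level of activity the read-out does not separate the two groups, although 2-nitrophenyl carries hydrogen-bond acceptors and 4-methylphenyl carries none, and the position therefore tolerates this exchange without a change that can be read. Nothing measured here bears on why the two groups stay so close.

From the compounds shown here alone, it remains open whether a different substituent on the phenyl ring at this sulfonyl sulfur, such as an amine or a carboxylic acid, or a longer alkyl chain in place of the aryl group, would move the number beyond the scatter. Going by these compounds, it also remains open whether the two aryl groups would stay this close in a read-out other than this assay, and whether the same exchange would behave alike on a core with a different ketone group.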